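Hydroxy in place of nitro on compound 2

The compounds below may be only part of what the source reports. "The series", "measured", "known", "first", "only" and "open" are said of these compounds alone.

In a functional assay, read by spectrophotometry, with a stated time of 2 h (on this read-out lower numbers stand for stronger inhibition and higher numbers for weaker inhibition), compound 1 `COC(=O)C1=C(C)NC(=O)NC1c1ccc(O)cc1` gives 3.14 ug/mL and compound 2 `CCOC(=O)C1=C(C)NC(=O)NC1c1ccc([N+](=O)[O-])cc1` gives 33.3 ug/mL as the higher of the two numbers. That gap lies beyond the usual scatter and marks compound 2 as the weaker inhibitor of the pair. The two compounds differ in more than one place, so the gap cannot be assigned to any single change. Compound 3 `CCOC(=O)C1=C(C)NC(=O)NC1c1ccc(O)cc1` has yet to be measured. It departs from compound 2 at one place only, with hydroxy in place of nitro on an aromatic carbon as the count of that change, which is hydroxy in place of nitro on an aromatic carbon. Going by the values given here, no step between measured compounds differing in one place is available to size it. Among the compounds with values here, the only guide is that compound 1, which also carries hydroxy, stands at 3.14 ug/mL on this read-out. A step to a lower number, beyond the scatter, is therefore expected in this assay for this change. An estimated 6.7-fold lower number from compound 2 to compound 3 (0.82 log units; beyond the scatter) is expected on that basis. Compound 3 is expected to give 5 ug/mL with 1.5 ug/mL to 20 ug/mL as the estimated range.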

Compound 3, half-maximal inhibitory concentration: 2.71 ug/mL
The estimate for compound 3 lay 1.8-fold (0.27 log units) above the measured number, within the range that was stated.
By their numbers in this assay, from the lowest: compounds 3 and 1 (each within the scatter of the next); then compound 2.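

In this assay, hydroxy in place of nitro on an aromatic carbon, para to a large group, gives a 12-fold lower number from compound 2 to compound 3 (1.09 log units; beyond the scatter), so this single exchange at this position is now sized as a large step on its own, with the rest of the structure held constant. The ester end behaves differently: methyl in place of hydrogen on a saturated chain carbon bound to an oxygen next to a carbonyl group gives a 1.2-fold lower number from compound 1 to compound 3 (0.06 log units; within the scatter), so with hydroxy on the aromatic ring, the methyl and ethyl esters cannot be told apart in this assay. Nothing in the data shown gives a measured property that would account for the size of the exchange at the aromatic carbon.

From the compounds shown here alone, with only hydroxy and nitro seen at this position, it remains open whether an amine, a methoxy group or a chlorine atom there would give a number close to that of compound 3 or close to that of compound 2. Going by these compounds, it also remains open how a longer chain on the ester, or a carboxylic acid in place of the ester, would read in this assay.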